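Notes on replacing pyridin-4-yl with 1H-imidazol-2-yl

A few compounds are considered here, and "the series" means these few. Any claim that something is new, unique, unknown or untested is made for them only; others in the source may bear on it.

Compound 1 `O=C(Nc1ccc(-c2cscn2)cc1)[C@@H]1CCCN(Cc2ccc(F)c(F)c2)C1`: 6000 nM
Compound 2 `O=C(Nc1ccc(-c2cscn2)cc1)C1CCCN(Cc2cc(F)c(F)c(F)c2)C1`: 400 nM
Compound 3 `O=C(Nc1ccc(-c2ccncc2)cc1)C1CCCN(Cc2ccc(F)c(F)c2)C1`: 600 nM

All three values come from a functional assay on A-375 cells (Homo sapiens) for antiproliferative activity; on this read-out higher numbers stand for weaker inhibition and lower numbers for stronger inhibition. Compound 3 lies within the scatter of compound 2, and its number is lower than that of compound 1 by a margin beyond the scatter. Compound 4 `O=C(Nc1ccc(-c2ncc[nH]2)cc1)C1CCCN(Cc2ccc(F)c(F)c2)C1` carries 1H-imidazol-2-yl in place of pyridin-4-yl on an aromatic carbon, para to a large group: 1H-imidazol-2-yl in place of pyridin-4-yl on an aromatic carbon. Among the measured compounds shown here, no pair of measured compounds differs in a single place, so the data show no direct step for this change. In this assay, no step beyond the scatter is the likeliest outcome, with a slight lean toward a higher number. The estimate therefore starts from compound 3 at 600 nM and keeps a wide range. The expected change is a 1.5-fold higher number from compound 3 to compound 4 (0.18 log units; within the scatter). For compound 4 the estimated value is 900 nM, with an expected range of 250 nM to 3500 nM.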

Compound 4, half-maximal inhibitory concentration: 19000 nM
Compound 4: middle estimate off by 21-fold (1.32 log units), on the low side; measured number outside the range, above it.
By their numbers in this assay, from the lowest: compounds 2 and 3 (each within the scatter of the next); then compound 1; then compound 4.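

In this assay, among the compounds shown here, replacing pyridin-4-yl with 1H-imidazol-2-yl on an aromatic carbon, para to a large group, gives a 32-fold higher number from compound 3 to compound 4 (1.50 log units; beyond the scatter) and is the first change that can be read in a single place. The read-out at this position therefore depends strongly on which aromatic ring is attached, even though the rest of the structure stays the same. Ring size, the number of hetero atoms and the hydrogen-bond donor all change together in this step, so the pair cannot separate them. Nothing available explains the size of the step.

Open, going by these compounds, is whether the donor or the five-membered ring accounts for the step. Phenyl and 1-methyl-1H-imidazol-2-yl at this position would help separate the two.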